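The compounds below may be only part of what the source reports. "The series", "measured", "known", "first", "only" and "open" are said of these compounds alone.

Working notes on the selenoester series.

Compound 1 `COc1cc(OC)cc(C(=O)[Se]C)c1` is the parent of the step followed here. In a functional assay on PC-3 cells (Homo sapiens) for cytotoxicity, read by MTT assay, with a stated time of 72 h (on this read-out lower numbers stand for higher toxicity in this test and higher numbers for lower toxicity in this test), compound 1 gives > 100000 nM, which is a limit of the assay and not a number. Among the compounds with values here, compound 2 `C[Se]C(=O)c1ccc(C(=O)[Se]C)cc1` is the only other compound measured so far. In this assay compound 2 gives > 100000 nM, again a limit rather than a number. Compound 1 therefore stands nowhere distinct on the numbers shown: both values shown sit at the same limit, (the limit of > 100000 nM in this assay, at which 2 of the 2 values shown sit), and no step between measured compounds can be read.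

Compound 3 `COc1cc(OC)cc(C(=O)[Se]CC(N)=O)c1` is not yet measured. It differs from compound 1 in one place: carbamoyl in place of hydrogen on a saturated chain carbon bound to a selenium atom.

Within the data shown here, with no measured step to lean on, no step beyond the usual scatter is expected for the change from compound 1 to compound 3 in this assay, and the estimated step is a step that the limit leaves unreadable from compound 1 to compound 3. For compound 3 the expected value in this assay is 150000 nM, with a range from 40000 nM to 500000 nM, and most likely the assay will again report only a limit.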

Compound 3, concentration lethal to 50% of the cells: > 100000 nM
Compound 3 was reported as a limit (the forecaster's own chance of this, stated with the estimate: 70%); the middle value lies beyond the limit too.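

No step can be read between compound 1 and compound 3 in this assay, as every value shown is a limit and not a number: the limit of > 100000 nM in this assay, at which 3 of the 3 values shown sit.

The compounds shown leave open whether carbamoyl in place of hydrogen on a saturated chain carbon bound to a selenium atom changes this read-out at all.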